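The source may hold more compounds than are shown below. What is called first, only, known or untested is meant among the compounds shown, and "the series" means these compounds.

Compound 1, with the structure `COc1ccc(-c2ncnn2-c2cc(OC)c(OC)c(OC)c2)cc1`, is measured in a functional assay on K562 cells (Homo sapiens) for antiproliferative activity, read by MTT assay, with a stated time of 72 h (on this read-out lower numbers stand for stronger inhibition and higher numbers for weaker inhibition), where compound 1 gives 950 nM. This is the only number shown for any compound here. Compound 2, with the structure `COc1cc(-c2ncnn2-c2ccc(N)cc2)cc(OC)c1OC`, gives > 10000 nM in this assay, which is a limit of the assay and not a number. One of the two values shown thus sits at the limit of > 10000 nM in this assay, at which 1 of the 2 values shown sits. Compound 3, with the structure `COc1cc(-n2ncnc2-c2ccc(SC)cc2)cc(OC)c1OC`, has not yet been measured. It differs from compound 1 in one place: methylsulfanyl in place of methoxy on an aromatic carbon. For the measured compounds named here, no measured pair in this set shows the effect of exchanging these two groups, so the expectation rests on compound 1 alone. The step from compound 1 to compound 3 is expected to be small, and the estimated step of a 1.1-fold lower number from compound 1 to compound 3 (0.02 log units; within the scatter) lies within the usual scatter of the measurement. Compound 3 is therefore expected to give about 900 nM in this assay, with a range from 300 nM to 3000 nM.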

Compound 3, half-maximal inhibitory concentration: 340 nM
Compound 3: middle estimate off by 2.6-fold (0.42 log units), on the high side, and the stated range covers the measured number.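

In this assay the exchange of 4-methoxyphenyl for 4-(methylsulfanyl)phenyl gives a 2.8-fold lower number from compound 1 to compound 3 (0.45 log units; beyond the scatter) and so keeps the activity of compound 1 and improves on it by a modest margin. The oxygen of the group gives way to sulfur and nothing else changes, yet the number moves, so this place, on an aromatic carbon para to a large group, is not indifferent to what sits on it. For the compounds shown here, until now no two compounds differing in one place could be compared, so this position had no measured step at all.

From the compounds shown here alone, whether a longer ethylsulfanyl chain or a single chlorine atom at this place would hold or extend the gain remains open. Nothing shown here explains why the sulfur-bearing group gives the lower number.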